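A Methylsulfonyl Group Replaces a Smaller Group

A few compounds are considered here, and "the series" means these few. Any claim that something is new, unique, unknown or untested is made for them only; others in the source may bear on it.

Of the compounds shown here, three have been tested so far, and none has given an exact dose. In a functional assay on the whole organism for antagonist activity, with Mus musculus as the target, in the maximal electroshock model (on this read-out higher numbers stand for an effect only at larger amounts of compound and lower numbers for an effect already at smaller amounts), compound 1 `Cn1c(-c2cccc(F)c2)nnc1S(C)(=O)=O` gives > 200 mg/kg as a limit of the test, not a measured dose. Compound 2 `CSc1n[nH]c(-c2ccc(F)cc2)n1` likewise gives > 200 mg/kg as a limit. Compound 3 `Cn1c(-c2ccccc2)nnc1[S+](C)[O-]` gives > 100 mg/kg as a limit too. Compound 3 therefore has no exact dose of its own, and it cannot be ranked against the other two.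

The next compound, compound 4 `Cn1c(-c2ccccc2)nnc1S(C)(=O)=O`, changes one place in compound 3. A methylsulfonyl group takes the place of the existing group on an aromatic carbon between two ring nitrogen atoms: a group of 4 heavy atoms (1 carbon, 2 oxygen, 1 sulfur; no ring) in place of a group of 3 heavy atoms (1 carbon, 1 oxygen, 1 sulfur; no ring), on an aromatic carbon.

Within the data shown here, no measured pair shows what a change like this does in this assay, so there is little to guide a prediction. The closest guide is compound 1, which also carries a methylsulfonyl group and has a limit of > 200 mg/kg in the same test. The estimated step that the limit leaves unreadable from compound 3 to compound 4 stays within the usual scatter, so no real change in either direction is expected. Compound 4 may well stop at a limit too. For compound 4 the estimated dose is 180 mg/kg and the expected range runs from 70 mg/kg to 400 mg/kg in this estimate.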

Compound 4, dose for half-maximal effect: > 200 mg/kg
Compound 4: no number, only a limit; the forecaster's own chance of this, stated with the estimate: 65%; middle value at least 1.1-fold (0.04 log units) from the limit.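

In this assay compound 4 gives > 200 mg/kg, which is a limit of the test and not a number. Among these compounds, compound 3 and compound 1 also stop at limits, and no step from either of them to compound 4 can be read. The compounds shown leave open whether either change alters the dose needed for an effect.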